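The source may report more compounds than this note shows. Statements on the series, on what has been measured and on what is new or still open speak of the compounds shown alone.

Two bis-indole hydroxamates have been measured. Compound 1 `O=C(CCCCCC(c1c(CC2COCCN2)[nH]c2ccccc12)c1c(CC2COCCN2)[nH]c2ccccc12)NO` and compound 2 `Cn1cc(C(CCCCCC(=O)NO)c2cn(C)c3ccccc23)c2ccccc21` share a chain that ends in the hydroxamic acid group, and both were tested in a functional assay on NCI-H460 cells (Homo sapiens) for cytotoxicity, read by sulforhodamine B assay, with a stated time of 24 h; a lower number here means a stronger inhibitor, a higher number a weaker inhibitor. In this assay compound 1 gives 1100 nM, and compound 2 gives 8800 nM, the higher of the two numbers, with compound 1 standing as the nearest and stronger neighbour, a gap that lies beyond the usual scatter.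

Compound 3 `CN(O)C(=O)CCCCCC(c1cn(C)c2ccccc12)c1cn(C)c2ccccc12` is the next member. It differs from compound 2 in a single way: methyl in place of hydrogen on an amide-type nitrogen. Among the measured compounds shown here, no measured pair shows this change, so the direction has to be judged from the change itself. A weaker result than compound 2 is expected, and the step from compound 2 is estimated as a 4.0-fold higher number from compound 2 to compound 3 (0.60 log units; beyond the scatter). Compound 3 is therefore estimated at 35000 nM, with a range from 9000 nM to 120000 nM.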

Compound 3, half-maximal inhibitory concentration: > 20000 nM
Compound 3: a limit, no number; the forecaster's own chance of this, stated with the estimate: 35%; the middle value lies beyond the limit too.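

Compound 3 gives > 20000 nM in this assay, and this is a limit of the assay, not a number. It still yields the first step read at this position: methyl in place of hydrogen on the amide-type nitrogen, whose other neighbours are the carbonyl carbon and oxygen, gives an at least 2.2-fold higher number from compound 2 to compound 3 (0.35 log units; beyond the scatter), so hydroxy(methyl)carbamoyl reads weaker than hydroxycarbamoyl on this core, by an amount that has only a lower bound. That step rests on a single limit: the limit of > 20000 nM in this assay, at which 1 of the 3 values shown sits.

The compounds shown leave open how far the true value of compound 3 lies past this limit, and whether the same methyl change would go the same way on the core of compound 1. They also leave open how an ethyl group on that nitrogen, or a carboxylic acid in place of the hydroxycarbamoyl group, would read.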